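A few compounds are considered here, and "the series" means these few. Any claim that something is new, unique, unknown or untested is made for them only; others in the source may bear on it.

Working notes on the series. The shared core is that of compound 1 `CC(C)CNC(=O)c1cc2ccc(OCc3ccccc3)cc2oc1=O`; in an in vitro assay on BTI-TN-5B1-4 cells for inhibition of Amine oxidase [flavin-containing] B (Homo sapiens), read by fluorescence (a higher number here means a weaker inhibitor, a lower number a stronger inhibitor), compound 1 gives 9590 nM. For the measured compounds named here, compound 2 `COc1ccc(NC(=O)c2cc3ccc(OCc4ccccc4)cc3oc2=O)cc1OC` gives 4390 nM in this assay, the lowest of the two numbers so far. Going by the values given here, the one measured step, a 2.2-fold lower number from compound 1 to compound 2 (0.34 log units; beyond the scatter), is modest but beyond the scatter. Compound 3 `COc1cc(NC(=O)c2cc3ccc(OCc4ccccc4)cc3oc2=O)cc(OC)c1` is not yet measured. It differs from compound 2 by 3,5-dimethoxyphenyl in place of 3,4-dimethoxyphenyl on an amide-type nitrogen. Among the compounds with values here, no measured step bears directly on this change: the step of a 2.2-fold lower number from compound 1 to compound 2 (0.34 log units; beyond the scatter) exchanges isobutyl for 3,4-dimethoxyphenyl, not one dimethoxyphenyl for another, so it offers no guide to the direction or size of moving a methoxy group. With nothing comparable to draw on, the expected step in this assay is a 1.0-fold higher number from compound 2 to compound 3 (0.00 log units; within the scatter), nothing beyond the scatter. Compound 3 is therefore estimated at about 4400 nM, within 1500 nM to 13000 nM.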

Compound 3, half-maximal inhibitory concentration: 3360 nM
For compound 3 the middle estimate is 1.3-fold (0.12 log units) above the measured one; measured number inside the range.
By their numbers in this assay, from the lowest: compounds 3 and 2 (each within the scatter of the next); then compound 1.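

In this assay, 3,5-dimethoxyphenyl in place of 3,4-dimethoxyphenyl on the amide-type nitrogen gives a 1.3-fold lower number from compound 2 to compound 3 (0.12 log units; within the scatter) and so does not separate these two arrangements of the same atoms at this position. The step of a 2.9-fold lower number from compound 1 to compound 3 (0.46 log units; beyond the scatter) for 3,5-dimethoxyphenyl in place of isobutyl is modest but beyond the scatter, so the change away from isobutyl now rests on two dimethoxyphenyl groups and not on one. There is no evidence on what lies behind these numbers.

The compounds shown leave open whether the methoxy groups contribute at all, as neither an unsubstituted phenyl nor a single methoxy on the phenyl ring stands among them. Also open, as far as these compounds go, is how other groups on this ring, such as a chlorine or a carboxylic acid, would read out.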